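A Catechol in Place of a Methoxyphenyl on a Weak Inhibitor

The compounds below may be only part of what the source reports. "The series", "measured", "known", "first", "only" and "open" are said of these compounds alone.

Compound 1 `CCOC(=O)c1cnn(-c2nc(-c3ccc(OC)cc3)c(C#N)c(=O)n2C)c1N` was tested in a functional assay, with a stated time of 150 min (on this read-out lower numbers stand for stronger inhibition and higher numbers for weaker inhibition), where compound 1 gives 79 ug/mL. Two other compounds were run in this assay. Compound 2 `CN(C)c1ccc(-c2nc(NN)n(C)c(=O)c2C#N)cc1` gives 69 ug/mL, and compound 3 `COc1cccc(-c2nc(SC)n(C)c(=O)c2C#N)c1OC` gives 67 ug/mL. The three numbers lie within the usual scatter of one another, so none of the three can be set apart from the others; compound 1 sits at the upper edge of this narrow cluster, but the gaps to compound 2 and to compound 3 are both within the scatter. No two of these compounds differ in a single place, so no single-point step has been measured.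

Compound 4 `CCOC(=O)c1cnn(-c2nc(-c3cccc(O)c3O)c(C#N)c(=O)n2C)c1N` has not yet been measured in this assay. It differs from compound 1 in one place: 2,3-dihydroxyphenyl in place of 4-methoxyphenyl on an aromatic carbon. Among the compounds with values here, no measured pair shows what this change does, and the three measured numbers offer no trend to lean on. The expected step is a 1.1-fold lower number from compound 1 to compound 4 (0.05 log units; within the scatter), which amounts to none beyond the scatter. Compound 4 is estimated at 70 ug/mL, with a range from 30 ug/mL to 160 ug/mL.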

Compound 4, half-maximal inhibitory concentration: 58 ug/mL
Estimate against measurement, compound 4: 1.2-fold (0.08 log units) above, within the range that was stated.
By their numbers in this assay, from the lowest: compounds 4, 3, 2 and 1 (each within the scatter of the next).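

In this assay, within the data shown here, this is the first single-place step in the set, and it falls on the aromatic carbon ortho to a cyano group: 2,3-dihydroxyphenyl in place of 4-methoxyphenyl gives a 1.4-fold lower number from compound 1 to compound 4 (0.13 log units; within the scatter), so compound 1 and compound 4 cannot be told apart. The position therefore tolerates a clear exchange of substituents, from a group with 0 hydrogen-bond donors to one with 2, without a step beyond the scatter, at least at the level of activity seen here. No measurement given here bears on why the read-out holds through this change.

The step swaps the methoxy group for two hydroxyl groups and moves the oxygens on the phenyl ring in the same change, so it cannot show whether either alteration alone would matter, or whether the two happen to offset each other. It also leaves open whether any group at this position can move the read-out beyond the scatter, for example a phenyl ring bearing an amine or a carboxylic acid, or a longer chain in place of the ring.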